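The compounds below may be only part of what the source reports. "The series", "measured", "known", "first", "only" and "open" are said of these compounds alone.

Among the measured compounds shown here, compound 2 `COC(C)CO[C@H](CC=C(C)C)C1=CC(=O)c2c(O)ccc(O)c2C1=O` is the only compound in the set with a number in a functional assay on DU-145 cells (Homo sapiens) for cytotoxicity, read by MTT assay; a higher number here means a weaker inhibitor, a lower number a stronger inhibitor: in this assay compound 2 gives 16600 nM. Compound 1 `CC(C)=CC[C@@H](OC(=O)c1ccco1)C1=CC(=O)c2c(O)ccc(O)c2C1=O` is reported only as a limit, and in this assay compound 1 gives > 100000 nM. For the measured compounds named here, the one measured step, an at least 6.0-fold lower number from compound 1 to compound 2 (0.77 log units; beyond the scatter), is itself anchored on a limit, (the limit of > 100000 nM in this assay, at which 1 of the 2 values shown sits), and swaps the whole group on the oxygen rather than its outer part. Compound 3 `CC(C)=CC[C@@H](OCCO)C1=CC(=O)c2c(O)ccc(O)c2C1=O` differs from compound 2 by hydroxymethyl in place of 1-methoxyethyl on a saturated chain carbon bound to an oxygen on a saturated carbon. That step offers no direct guide, so a change within scatter is expected, a 1.0-fold lower number from compound 2 to compound 3 (0.02 log units; within the scatter), and compound 3 is estimated at 16000 nM (range 5000 nM to 50000 nM).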

Compound 3, half-maximal inhibitory concentration: 9900 nM
Compound 3: the middle estimate sits 1.6-fold (0.21 log units) above what was measured; measured number inside the range.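

Swapping 1-methoxyethyl for hydroxymethyl at this position, which brings in a hydrogen-bond donor, does not separate the two chains in this assay (a 1.7-fold lower number from compound 2 to compound 3 (0.22 log units; within the scatter)). Compounds 2 and 3 thus both stand apart from the (furan-2-yl)carbonyl group on this oxygen, and the 2-hydroxyethyl chain repeats what 2-methoxypropyl showed (an at least 10-fold lower number from compound 1 to compound 3 (1.00 log units; beyond the scatter)). On these data alone, the size of that step stays open-ended, as the value of compound 1 is a limit: the limit of > 100000 nM in this assay, at which 1 of the 3 values shown sits. As far as these compounds go, whether an amine, a carboxylic acid or a longer chain in place of hydroxymethyl would give a clearly lower number remains open.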